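The source may hold more compounds than are shown below. What is called first, only, known or untested is meant among the compounds shown, and "the series" means these compounds.

Measured compounds:
compound 1 `Cc1ccc(COc2ccc(C(=O)NC(=S)Nc3ccc(C)c(-c4nc5ccccc5[nH]4)c3)cc2)cc1`: 14200 nM
compound 2 `Cc1ccc(NC(=O)NC(=O)c2ccc(OCc3cccc(Cl)c3)cc2)cc1-c1nc2ccccc2[nH]1`: 15400 nM

Of the compounds shown here, two have been measured in a functional assay on HT-29 cells (Homo sapiens) for inhibition, read by MTT assay, with a stated time of 48 h; on this read-out lower numbers stand for stronger inhibition and higher numbers for weaker inhibition. Compound 1 gives 14200 nM there, and compound 2 gives 15400 nM; the two values lie within the scatter of each other, so compound 2 stands level with compound 1 on the numbers shown rather than apart from it. Compound 3 `Cc1ccc(NC(=O)NC(=O)c2ccc(OCc3ccccc3Cl)cc2)cc1-c1nc2ccccc2[nH]1` has not yet been measured. It differs from compound 2 in one place: 2-chlorophenyl in place of 3-chlorophenyl on a saturated chain carbon bound to an oxygen on an aromatic ring. Within the data shown here, no measured pair shows what such a rearrangement does on this series, so nothing in the data points in either direction. In the absence of such a step, the expectation for compound 3 is a change of a 1.0-fold lower number from compound 2 to compound 3 (0.01 log units; within the scatter), that is, no step beyond the scatter. Compound 3 is therefore estimated at 15000 nM, with a range from 5000 nM to 45000 nM.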

Compound 3, half-maximal inhibitory concentration: 9010 nM
Compound 3: middle estimate off by 1.7-fold (0.22 log units), on the high side; the measured number falls inside the stated range.
By their numbers in this assay, from the lowest: compounds 3, 1 and 2 (each within the scatter of the next).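

In this assay, 2-chlorophenyl in place of 3-chlorophenyl on a saturated chain carbon bound to an oxygen on an aromatic ring gives a 1.7-fold lower number from compound 2 to compound 3 (0.23 log units; within the scatter) within the scatter. Among these compounds, this is the first single-place comparison, and on these numbers the two chlorophenyl isomers cannot be told apart at this position. That reading rests on this one pair, and no measurement shown offers an explanation for the size of the step.

From the compounds shown here alone, whether the chlorine itself matters here stays open, since nothing shows what a plain phenyl, a methoxy group or a carboxylic acid in its place would do. Compound 1 differs from compound 2 in more than one place, so it cannot settle that question.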